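This account rests on a few compounds, and the source may have more. Where it says the series, first, only, none or still open, it means among the compounds named here.

Compound 1 `COc1cc(Cl)cc(-c2nn(-c3cccc(NC(=O)c4cccc(C(F)(F)F)c4)c3)cc2-c2ccncc2)c1`: 69%
Compound 2 `O=C(Nc1cccc(-n2cc(-c3ccncc3)c(-c3cc(O)cc(Cl)c3)n2)c1)c1cc(C(F)(F)F)cc(C(F)(F)F)c1`: 96%

In a functional assay on NCI-H226 cells (Homo sapiens) for inhibition, read by sulforhodamine B assay, with a stated time of 48 h, tested at 10 uM (on this read-out lower numbers stand for a stronger effect and higher numbers for a weaker effect at the one concentration tested), compound 2 gives the highest of the two numbers, so the weaker effect, and compound 1 stands lower by a gap beyond the usual scatter. Compound 3 `COc1cc(Cl)cc(-c2nn(-c3cccc(NC(=O)c4cc(C(F)(F)F)cc(C(F)(F)F)c4)c3)cc2-c2ccncc2)c1` has not yet been measured. It differs from compound 2 by methyl in place of hydrogen on an oxygen on an aromatic ring. For the measured compounds named here, no measured pair shows this change on its own, so its effect is uncertain. A modest step toward lower numbers, or none beyond the scatter, is expected in this assay. Compound 3 is estimated at 86%, within 62% to 100%, an expected step of a number 10 percentage points lower from compound 2 to compound 3 (within the scatter).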

Compound 3, a percentage reported as activity, at one concentration (the size of the read-out at that concentration, not a potency): 76%
The estimate for compound 3 lay 10 percentage points above the measured number, within the range that was stated.
By their numbers in this assay, from the lowest: compounds 1 and 3 (each within the scatter of the next); then compound 2.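

In this assay, the change from hydroxy to methoxy on this aromatic ring gives a number 20 percentage points lower from compound 2 to compound 3 (beyond the scatter) and so shows that capping this oxygen with methyl strengthens the effect in this pair. With the methoxy in place, trifluoromethyl in place of hydrogen on an aromatic carbon gives a number 7 percentage points higher from compound 1 to compound 3 (within the scatter) and so cannot be told apart from no change. Nothing available explains either result.

On these data alone, whether an ethoxy group or an amine at this position would give a stronger effect remains open. So does whether the hydroxy to methoxy step would be the same with only one trifluoromethyl group.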